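Swapping Dihydroxyphenyl for Dichlorophenyl: Expected Inhibition

The source may report more compounds than this note shows. Statements on the series, on what has been measured and on what is new or still open speak of the compounds shown alone.

Compound 1 `Cn1cnc2c(N3CCCCC3)nc(-c3ccccc3O)nc21`: in an assay on cells for displacement of a labelled ligand from adenosine receptor A2b (Homo sapiens), read by scintillation counting and radioligand binding, with a stated time of 30 min, tested at 10 uM (a higher number here means more inhibition at the concentration tested (going by the name of the read-out), a lower number less inhibition), compound 1 gives 30.2%.
Compound 2 `Cn1cnc2c(N3CCCCC3)nc(-c3cccc(O)c3O)nc21`: in this assay compound 2 gives 26%.
Compound 3 `CN1CCN(c2nc(-c3ccc(Cl)c(Cl)c3)nc3c2ncn3C)CC1`: in this assay compound 3 gives 28.3%.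

Compound 2 holds the lowest of the three numbers, yet both neighbours lie within the scatter of it, compound 3 nearer and compound 1 further, so no order among them can be read. Compound 4 `Cn1cnc2c(N3CCCCC3)nc(-c3cc(Cl)ccc3Cl)nc21` differs from compound 2 by 2,5-dichlorophenyl in place of 2,3-dihydroxyphenyl on an aromatic carbon. Going by the values given here, the only one-place step measured, a number 4.2 percentage points lower from compound 1 to compound 2 (within the scatter), stayed within the scatter and concerns a hydroxy, not this swap. Compound 3, which also carries a dichlorophenyl, sits within the scatter of compound 2. No step beyond the scatter is therefore expected in this assay. Compound 4 is expected to give 30%, between 15% and 46%, a step of a number 4 percentage points higher from compound 2 to compound 4 (within the scatter) expected to remain within the scatter.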

Compound 4, a percentage reported as inhibition, at one concentration (the size of the read-out at that concentration, not a potency): 31%
Estimate against measurement, compound 4: 1 percentage points below, within the range that was stated.
By their numbers in this assay, from the lowest: compounds 2, 3, 1 and 4 (each within the scatter of the next).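

At this aromatic carbon, between two ring nitrogen atoms, this assay shows a number 5 percentage points higher from compound 2 to compound 4 (within the scatter) when 2,5-dichlorophenyl replaces 2,3-dihydroxyphenyl, and a number 0.8 percentage points higher from compound 1 to compound 4 (within the scatter) when it replaces 2-hydroxyphenyl. The entering group has no hydrogen-bond donors or acceptors, yet neither swap gives a step beyond the scatter, so these compounds do not separate the groups at this position. No measured evidence accounts for this result.

On these data alone, whether an amine or a carboxylic acid on this phenyl ring would give a step beyond the scatter stays open. So does the effect of a longer chain at this carbon.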